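The source may hold more compounds than are shown below. What is called first, only, known or untested is meant among the compounds shown, and "the series" means these compounds.

Compound 1 `CNC(=O)/C=C/c1ccc(NC(=O)Nc2ccc(Cl)c(C(F)(F)F)c2)cc1` and compound 3 `CC1CN(C(=O)/C=C/c2ccc(NC(=O)Nc3ccc(Cl)c(C(F)(F)F)c3)cc2)CC(C)O1` share a core; the two differ by 2,6-dimethylmorpholin-4-yl in place of methylamino on a carbonyl carbon. In a functional assay on HepG2 cells (Homo sapiens) for inhibition, read by MTT assay, with a stated time of 120 h (a lower number here means a stronger inhibitor, a higher number a weaker inhibitor), compound 1 gives 20400 nM, and compound 3 gives 45900 nM, a step of a 2.3-fold higher number from compound 1 to compound 3 (0.35 log units; beyond the scatter). Compound 2 `CNC(=O)/C(C)=C/c1ccc(NC(=O)Nc2ccc(Cl)c(C(F)(F)F)c2)cc1` differs from compound 1 by 2-(methylcarbamoyl)prop-1-en-1-yl in place of 2-(methylcarbamoyl)ethenyl on an aromatic carbon; in this assay compound 2 gives 44300 nM, a step of a 2.2-fold higher number from compound 1 to compound 2 (0.34 log units; beyond the scatter). Compound 4 `C/C(=C\c1ccc(NC(=O)Nc2ccc(Cl)c(C(F)(F)F)c2)cc1)C(=O)N1CC(C)OC(C)C1` is not yet measured. It stands to compound 2 as compound 3 stands to compound 1: the change is 2,6-dimethylmorpholin-4-yl in place of methylamino on a carbonyl carbon, at a place described in the same words as for the first pair, so this is the same change on the second core. The step from compound 2 to compound 4 is expected to be about a 2.1-fold higher number from compound 2 to compound 4 (0.33 log units; beyond the scatter), resting on the earlier step of a 2.3-fold higher number from compound 1 to compound 3 (0.35 log units; beyond the scatter) being carried over to compound 2 from its value 44300 nM. The expected value for compound 4 in this assay is therefore 95000 nM, likely between 35000 nM and 260000 nM.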

Compound 4, half-maximal inhibitory concentration: > 50000 nM
Compound 4: a limit, no number; the forecaster's own chance of this, stated with the estimate: 25%; the middle value lies beyond the limit too.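

In this assay compound 4 gives > 50000 nM as a limit of the assay, not a number. Placing 2,6-dimethylmorpholin-4-yl in place of methylamino on the core of compound 2 therefore yields only a floor, an at least 1.1-fold higher number from compound 2 to compound 4 (0.05 log units; that floor lies within the scatter), and the true size of the step on this core remains unknown. The result neither confirms nor contradicts that the change carries over unchanged from one core to the other: the same change on two cores in this assay, a 2.3-fold higher number (0.35 log units; beyond the scatter) from compound 1 to compound 3 and an at least 1.1-fold higher number (0.05 log units; that floor lies within the scatter) from compound 2 to compound 4; the limit leaves it open whether they differ.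

The compounds shown leave open how a plain morpholin-4-yl or a dimethylamino group on the same carbonyl carbon would read on either core. They also leave open whether a change at the chlorine or trifluoromethyl groups would shift these values.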